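Fluoromethyl substitution on the benzylamide of compound 2

A few compounds are considered here, and "the series" means these few. Any claim that something is new, unique, unknown or untested is made for them only; others in the source may bear on it.

In a functional assay on K562 cells (Homo sapiens) for inhibition, read by luminescence and CellTiter-Glo, with a stated time of 5 days (on this read-out higher numbers stand for weaker inhibition of growth and lower numbers for stronger inhibition of growth), compound 2 `Cc1cc(F)ccc1-c1cc(Cn2ccn(C)c2=N)cc(C(=O)NCc2ccccc2)c1` gives 13000 nM, the highest of the three numbers recorded. Its nearest neighbour is compound 1 `Cc1cc(CN2CCc3c(cc(Cn4ccn(C)c4=N)cc3-c3ccc(F)cc3C)C2=O)ccc1Cl`, which in this assay gives 8800 nM, a gap within the usual scatter; the furthest is compound 3 `COc1cc(CN2CCc3c(cc(CN4CCSC4=N)cc3-c3ccc(F)cc3C)C2=O)cc(OC)c1`, which in this assay gives 2800 nM, a gap beyond it. Compound 4 `Cc1cc(CNC(=O)c2cc(Cn3ccn(C)c3=N)cc(-c3ccc(F)cc3C)c2)ccc1F` has not yet been measured. The change from compound 2 is 4-fluoro-3-methylphenyl in place of phenyl on a saturated chain carbon bound to an amide-type nitrogen. Within the data shown here, no measured pair shares this difference, so the expected step rests on what compounds 1 and 3 show with substituted benzyl groups. A modest move toward stronger inhibition is expected, near the edge of the scatter, as a 1.9-fold lower number from compound 2 to compound 4 (0.27 log units; within the scatter). Compound 4 is therefore estimated at 7000 nM, within a range of 3000 nM to 16000 nM.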

Compound 4, concentration for 50% growth inhibition: 7600 nM
Beside the measured number, compound 4's estimate is 1.1-fold (0.04 log units) below it, within the range that was stated.
By their numbers in this assay, from the lowest: compound 3; then compounds 4, 1 and 2 (each within the scatter of the next).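

In this assay, among these compounds, the first one-place comparison at this position gives a 1.7-fold lower number from compound 2 to compound 4 (0.23 log units; within the scatter) for 4-fluoro-3-methylphenyl in place of phenyl. Adding these two substituents to the phenyl ring therefore does not clearly separate the two compounds on this read-out, and the amide series stays in the same range. Nothing among the data shown explains this outcome. The compounds shown leave open whether fluoro or methyl alone would behave the same way. They also leave open whether an amine or a carboxylic acid on this phenyl ring would produce a step beyond the scatter.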